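The source may report more compounds than this note shows. Statements on the series, on what has been measured and on what is new or still open speak of the compounds shown alone.

Measured in a functional assay on COR-L23 cells (Homo sapiens) for antiproliferative activity, read by CellTiter-Glo, with a stated time of 72 h; on this read-out lower numbers stand for stronger inhibition and higher numbers for weaker inhibition:
- compound 1 `CCC(=O)N[C@@H](C)c1ccc(NC(=O)N2CC(c3ccc(N)nc3)C2)cc1`: 120 nM
- compound 2 `C[C@H](NC(=O)c1cccc(F)c1)c1ccc(NC(=O)N2CC(c3cncc(N)c3)C2)cc1`: 630 nM
- compound 3 `C[C@H](NC(=O)c1ncccn1)c1ccc(NC(=O)N2CC(c3cncc(N)c3)C2)cc1`: 1380 nM

Compound 3 stands highest of the three at 1380 nM, which makes it the weakest so far. Compound 2 is its nearest neighbour, and compound 1 lies furthest away.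

The next compound is compound 4 `CCC(=O)N[C@@H](C)c1ccc(NC(=O)N2CC(c3cncc(N)c3)C2)cc1`, with ethyl in place of pyrimidin-2-yl on a carbonyl carbon. The same difference reads as (pyrimidin-2-yl)carbonyl to propanoyl.

Among the measured compounds shown here, only one measured step acts at this place: a 2.2-fold higher number from compound 2 to compound 3 (0.34 log units; beyond the scatter), with pyrimidin-2-yl in place of 3-fluorophenyl on a carbonyl carbon. That step is modest and compares two ring groups, so it says little directly about a group with no ring. The closest guide is compound 1, which carries the same propanoylamino group on a core that differs from that of compound 4. Compound 1 gives 120 nM. How far that value carries over to the core of compound 3 is not known from these data.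

In this assay a moderate to large step towards a lower number is therefore expected, beyond the scatter. The expected change is a 5.5-fold lower number from compound 3 to compound 4 (0.74 log units; beyond the scatter). For compound 4 the estimated value is 250 nM, with an expected range from 80 nM to 750 nM.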

Compound 4, half-maximal inhibitory concentration: 1580 nM
The estimate for compound 4 lay 6.3-fold (0.80 log units) below the measured number; measured number outside the range, above it.
By their numbers in this assay, from the lowest: compound 1; then compound 2; then compounds 3 and 4 (each within the scatter of the next).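

On the carbonyl carbon, pyrimidin-2-yl and ethyl cannot be told apart in this assay (a 1.1-fold higher number from compound 3 to compound 4 (0.06 log units; within the scatter)), so on this core the ring with its two nitrogens and the two-carbon ethyl group give matching read-outs. The 3-fluorophenyl group does stand apart from ethyl at this place, although only by a modest step (a 2.5-fold higher number from compound 2 to compound 4 (0.40 log units; beyond the scatter)), so the acyl position shows some sensitivity, but within a narrow span across these three groups. The large step lies at the other place, on the saturated ring carbon: with the propanoylamino group held constant, 5-aminopyridin-3-yl in place of 6-aminopyridin-3-yl gives a 13-fold higher number from compound 1 to compound 4 (1.12 log units; beyond the scatter), so the low number of compound 1 belongs to the 6-aminopyridin-3-yl compound and does not transfer to the 5-aminopyridin-3-yl series.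

Still open, going by these compounds, is whether a longer chain, a cyclopropyl ring or an amine-bearing acyl group on this carbonyl carbon would separate from ethyl, and whether the 3-fluorophenyl, pyrimidin-2-yl and ethyl groups would keep the same order on the 6-aminopyridin-3-yl compounds. Nothing available here accounts for either the large step or the modest one.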